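A few compounds are considered here, and "the series" means these few. Any claim that something is new, unique, unknown or untested is made for them only; others in the source may bear on it.

Compound 1 `COc1ccc(/C=C2\CN(C)C/C(=C\c3cccnc3)C2=O)c(OC)c1OC`: 5160 nM
Compound 2 `O=C1/C(=C/c2cccnc2)CNC/C1=C\c1ccccc1F`: 21000 nM
Compound 3 `O=C1/C(=C/c2ccncc2)CNC/C1=C\c1ccccc1F`: 8200 nM

All three values come from a functional assay on HepG2 cells (Homo sapiens) for cytotoxicity, read by MTT assay, with a stated time of 24 h; a higher number here means a weaker inhibitor, a lower number a stronger inhibitor. Compound 3, at 8200 nM, lies within the scatter of compound 1 and clearly under compound 2. Compound 4 `O=C1/C(=C/c2ccncc2)CN(S(=O)(=O)c2ccc(Cl)cc2)C/C1=C\c1ccccc1F` places (4-chlorophenyl)sulfonyl in place of hydrogen on the amine nitrogen in the ring of compound 3: (4-chlorophenyl)sulfonyl in place of hydrogen on an amine nitrogen in a ring. For the measured compounds named here, the only measured step, a 2.6-fold lower number from compound 2 to compound 3 (0.41 log units; beyond the scatter), concerns pyridin-4-yl in place of pyridin-3-yl, so it offers a rough scale and nothing specific to this nitrogen. Going by the values given here, no measured step covers a change at that nitrogen, so the direction is tentative. A moderately lower number is expected, a 2.9-fold lower number from compound 3 to compound 4 (0.47 log units; beyond the scatter). For compound 4 the estimate is 2800 nM, with an expected range of 700 nM to 10000 nM.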

Compound 4, half-maximal inhibitory concentration: 5300 nM
Estimate against measurement, compound 4: 1.9-fold (0.28 log units) below; the measured number falls inside the stated range.
By their numbers in this assay, from the lowest: compounds 1, 4 and 3 (each within the scatter of the next); then compound 2.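

In this assay the amine nitrogen in the ring takes (4-chlorophenyl)sulfonyl in place of hydrogen with a 1.5-fold lower number from compound 3 to compound 4 (0.19 log units; within the scatter) as the whole step, so 10 heavy atoms enter at this nitrogen without a shift beyond the scatter. For the compounds shown here, this is the first reading at this position, and it concerns one group on one parent only. Nothing measured on these compounds bears on why the step is this small.

Going by these compounds, whether an acetyl or benzyl group on this nitrogen reads the same stays open. So does whether the same sulfonyl change holds with pyridin-3-yl in place of pyridin-4-yl.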